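A few compounds are considered here, and "the series" means these few. Any claim that something is new, unique, unknown or untested is made for them only; others in the source may bear on it.

In a functional assay on NCI-H460 cells (Homo sapiens) for cytotoxicity, read by MTT assay, with a stated time of 72 h (on this read-out higher numbers stand for weaker inhibition and lower numbers for stronger inhibition), compound 1 `CCN(CC)Cc1ccc2nc(NC(=O)N/N=C/c3cn(Cc4ccc(C)cc4)c4ccccc34)sc2c1` gives 320 nM, compound 2 `Cc1ccc(Cn2cc(/C=N/NC(=O)Nc3nc4ccc(CN5CCC(C)CC5)cc4s3)c3ccccc32)cc1` gives 410 nM and compound 3 `Cc1ccc(Cn2cc(/C=N/NC(=O)Nc3nc4ccc(CN(C)C)cc4s3)c3ccccc32)cc1` gives 200 nM. All three carry the 4-methylbenzyl group and differ only in the group on a saturated chain carbon bound to an aromatic carbon. Compound 2 sits at the upper end of this small range, but it shares that place, as the measured step is a 1.3-fold higher number from compound 1 to compound 2 (0.11 log units; within the scatter). Within the data shown here, only one step clears the scatter, and modestly: a 2.1-fold lower number from compound 2 to compound 3 (0.31 log units; beyond the scatter). The remaining step is a 1.6-fold lower number from compound 1 to compound 3 (0.20 log units; within the scatter).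

Compound 4 `CC1CCN(Cc2ccc3nc(NC(=O)N/N=C/c4cn(Cc5ccc(Cl)cc5)c5ccccc45)sc3c2)CC1` keeps the 4-methylpiperidin-1-yl group of compound 2 and changes the other end of the molecule, with chloro in place of methyl on an aromatic carbon, para to a large group, so that 4-methylbenzyl becomes 4-chlorobenzyl (chloro in place of methyl on an aromatic carbon). Among the measured compounds shown here, no measured step touches this place, so the three steps bear on it only indirectly, by showing how narrow the numbers have stayed for a change elsewhere. No direction can be drawn from them, and no shift beyond the scatter is expected in this assay. The expected step is a 1.0-fold lower number from compound 2 to compound 4 (0.01 log units; within the scatter). For compound 4 the estimated value is 400 nM, with an expected range of 170 nM to 900 nM.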

Compound 4, half-maximal inhibitory concentration: 400 nM
Compound 4: middle estimate and measured number agree at the digits printed, and the stated range covers the measured number.
By their numbers in this assay, from the lowest: compounds 3, 1, 4 and 2 (each within the scatter of the next, the first and the last beyond it).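

Among these compounds, the replacement of methyl by chloro on the aromatic carbon, para to a large group, turns 4-methylbenzyl into 4-chlorobenzyl and is the first measured change at this end of the molecule. In this assay the step is a 1.0-fold lower number from compound 2 to compound 4 (0.01 log units; within the scatter) and so gives no readable shift with the 4-methylpiperidin-1-yl group held fixed, something the three earlier compounds could not show, as they differ only in the group at the other end. Nothing measured on these compounds speaks to the reason for so flat a step.

The compounds shown leave open whether this position stays as flat with a group of a different kind in place of chloro or methyl, such as a methoxy group, a nitro group, a carboxylic acid or a plain hydrogen. Also open, from the compounds shown here alone, is whether chloro in place of methyl reads the same when the 4-methylpiperidin-1-yl group gives way to the dimethylamino group of compound 3 or the diethylamino group of compound 1.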